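The source may report more compounds than this note shows. Statements on the series, on what has been measured and on what is new or still open speak of the compounds shown alone.

Measured in a functional assay on HCT-116 cells (Homo sapiens) for antiproliferative activity, read by sulforhodamine B assay, with a stated time of 72 h; on this read-out lower numbers stand for stronger inhibition and higher numbers for weaker inhibition:
- compound 1 `COc1ncc(-c2ccc3ncc(NCc4ccc(C(F)(F)F)cc4)c(OC)c3c2)cc1NS(=O)(=O)c1ccc(F)cc1F`: 3220 nM
- compound 2 `COc1ncc(-c2ccc3ncc(NC(=O)CN4CCN(C)CC4)c(OC)c3c2)cc1NS(=O)(=O)c1ccc(F)cc1F`: 1540 nM

Of these two compounds, compound 2 has the lower number in this assay, at 1540 nM. Compound 3 `COc1ncc(-c2ccc3ncc(NCC4CCN(C(C)=O)CC4)c(OC)c3c2)cc1NS(=O)(=O)c1ccc(F)cc1F` is the next to be considered, and it differs from compound 2 as follows: (1-acetylpiperidin-4-yl)methyl in place of ((4-methylpiperazin-1-yl)methyl)carbonyl on a nitrogen on an aromatic ring. Going by the values given here, the one measured step that bears on this change is a 2.1-fold lower number from compound 1 to compound 2 (0.32 log units; beyond the scatter), a modest step at the same nitrogen on an aromatic ring. Among the compounds with values here, a modest rise is therefore expected, though with only this step to go on, the direction is uncertain. The expected change is a 1.6-fold higher number from compound 2 to compound 3 (0.19 log units; within the scatter). For compound 3 the estimated value is 2400 nM, with an expected range of 900 nM to 6000 nM.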

Compound 3, half-maximal inhibitory concentration: 1930 nM
The estimate for compound 3 lay 1.2-fold (0.09 log units) above the measured number; the measured number falls inside the stated range.
By their numbers in this assay, from the lowest: compounds 2, 3 and 1 (each within the scatter of the next, the first and the last beyond it).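

In this assay, (1-acetylpiperidin-4-yl)methyl in place of ((4-methylpiperazin-1-yl)methyl)carbonyl on this nitrogen gives a 1.3-fold higher number from compound 2 to compound 3 (0.10 log units; within the scatter) and so separates the two only within the scatter, even though the entering group has one ring hetero atom where the leaving group has two. With 1-acetylpiperidin-4-yl in place of 4-(trifluoromethyl)phenyl, the data show a 1.7-fold lower number from compound 1 to compound 3 (0.22 log units; within the scatter) and thus no separation beyond the scatter either. Nothing available explains these small steps. Still open, from the compounds shown here alone, is whether a simple primary amine, a carboxylic acid or a longer chain on this nitrogen would carry the number outside this narrow span.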